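Changing the Aryl Group on the Shared Core

The source may hold more compounds than are shown below. What is called first, only, known or untested is meant among the compounds shown, and "the series" means these compounds.

Measured compounds:
Compound 1: `CC(C)C[C@H](N)CN(C(=O)[C@@H]1C[C@H]1c1ccccc1)c1ccc(C2=CCCC2)cc1` — 1200 nM
Compound 2: `COc1ccccc1-c1ccc(N(C[C@@H](N)CC(C)C)C(=O)[C@@H]2C[C@H]2c2ccccc2)cc1` — 3200 nM

Both were tested in a functional assay for agonist activity at G protein-coupled receptor 88 (Homo sapiens), read by HTRF and cAMP accumulation; a higher number here means that more compound is needed for the effect, a lower number that less compound is needed. Compound 2 stands at the highest of the two numbers; its nearest neighbour is compound 1, and the step of a 2.7-fold higher number from compound 1 to compound 2 (0.43 log units; beyond the scatter) lies beyond the scatter. Compound 3, `CC(C)C[C@H](N)CN(C(=O)[C@@H]1C[C@H]1c1ccccc1)c1ccc(-c2ccc(C#N)cc2)cc1`, has not been measured. It differs from compound 2 by 4-cyanophenyl in place of 2-methoxyphenyl on an aromatic carbon.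

Among the compounds with values here, only one measured step bears on this change, and it concerns a different pair of groups: the step from compound 1 to compound 2 shows that replacing the group at this place moves the number by a modest amount. Within the data shown here, no measured compound carries a 4-cyanophenyl, so the direction for compound 3 cannot be read from the data. The estimate for compound 3 is therefore centred near the value of compound 2, with a wide range: 2800 nM, between 900 nM and 9000 nM. This means an expected step of a 1.1-fold lower number from compound 2 to compound 3 (0.06 log units; within the scatter), which is within the scatter.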

Compound 3, half-maximal effective concentration: 670 nM
Beside the measured number, compound 3's estimate is 4.2-fold (0.62 log units) above it; measured number outside the range, below it.
By their numbers in this assay, from the lowest: compounds 3 and 1 (each within the scatter of the next); then compound 2.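

Within this assay, the result shows that the number at this place does not simply rise when an aromatic ring is attached, as the one earlier step might have suggested: a 4.8-fold lower number from compound 2 to compound 3 (0.68 log units; beyond the scatter). 2-Methoxyphenyl and 4-cyanophenyl have the same counts of heavy atoms and hydrogen-bond acceptors, so those counts alone do not fix the number, while the step of a 1.8-fold lower number from compound 1 to compound 3 (0.25 log units; within the scatter) leaves 4-cyanophenyl and cyclopent-1-en-1-yl indistinguishable here. Nothing available explains the difference between the aryl groups.

The two aryl groups differ both in the substituent they carry and in where it sits, so the compounds shown cannot separate these two changes. As far as these compounds go, how an unsubstituted phenyl or a pyridyl ring would behave at this place remains open.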